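A few compounds are considered here, and "the series" means these few. Any claim that something is new, unique, unknown or untested is made for them only; others in the source may bear on it.

Measured compounds in a functional assay on CHO-K1 cells for antagonist activity at transient receptor potential cation channel subfamily V member 1 (Homo sapiens), read by FLIPR; a lower number here means a stronger inhibitor, a higher number a weaker inhibitor:

compound 1 `CC(C(=O)NCc1ccc(C(F)(F)F)nc1)c1ccc(NS(C)(=O)=O)c(F)c1`: "not active" (no number reported)
compound 2 `Cc1ccc(Nc2nc(C(F)(F)F)ccc2CNC(=O)C(C)c2ccc(NS(C)(=O)=O)c(F)c2)cc1C`: 1160 nM
compound 3 `CC(C(=O)NCc1ccc(C(F)(F)F)nc1NCc1ccc(Cl)cc1)c1ccc(NS(C)(=O)=O)c(F)c1`: 414 nM

Compound 1 carries only hydrogen on the aromatic carbon next to the ring nitrogen of its shared core, and in this assay compound 1 is reported as "not active" (no number reported), without a number. Among the compounds with values here, compounds 2 and 3 each carry a substituted nitrogen on that same carbon, and both give measurable values; the one recorded step, a 2.8-fold lower number from compound 2 to compound 3 (0.45 log units; beyond the scatter), shows that swapping the group on that nitrogen moves the number only modestly.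

Compound 4 `CC(C(=O)NCc1ccc(C(F)(F)F)nc1N1CCC(C)(C)CC1)c1ccc(NS(C)(=O)=O)c(F)c1` differs from compound 1 by a single change: 4,4-dimethylpiperidin-1-yl in place of hydrogen on an aromatic carbon. The substituent enters at the position that, in compounds 2 and 3, separates an inactive compound from active ones. The step from compound 2 to compound 3 bears on it only indirectly, since it varies the group at that position rather than adding one, and its size was modest. The expectation is therefore that filling this position takes compound 4 from the inactive result of compound 1 into the range where compounds 2 and 3 sit, with wide uncertainty.

Compound 4 is estimated at 600 nM, within 150 nM to 3000 nM.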

Compound 4, half-maximal inhibitory concentration: 8 nM
Compound 4: middle estimate off by 75-fold (1.88 log units), on the high side, outside the stated range (below it).
By their numbers in this assay, from the lowest: compound 4; then compound 3; then compound 2.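

The new result gives a 52-fold lower number from compound 3 to compound 4 (1.71 log units; beyond the scatter) and a 150-fold lower number from compound 2 to compound 4 (2.16 log units; beyond the scatter) in this assay and so shows that the choice of group at this aromatic carbon can matter far more than the modest earlier step suggested. Compounds 2 and 3 had shown that a substituted nitrogen here goes with a measurable value, but not that one group could stand so far ahead of the others. In compound 4 that nitrogen sits inside a six-membered non-aromatic ring, while compounds 2 and 3 carry an open amino link to an aryl or benzyl group, and nothing measured here explains why this swap lowers the number so sharply.

Compound 1 has no number, so the size of the change from hydrogen to 4,4-dimethylpiperidin-1-yl cannot be read. The compounds shown also leave open whether the ring alone is enough or the two methyl groups are needed, a question that plain piperidin-1-yl, morpholin-4-yl or open-chain diethylamino at the same carbon would help to settle.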